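The compounds below may be only part of what the source reports. "The series", "measured", "known", "first", "only" and "open" are said of these compounds alone.

Going by the values given here, compound 2, `CN(CCN1CCCCC1)c1ccc(Cn2c(=O)[nH]c3c(N)nc(C(F)(F)F)cc32)cn1`, is the only compound of this set with a number in an in vitro ADME assay on microsomes from liver (Homo sapiens) for pharmacokinetics (a lower number here means slower removal, a higher number faster removal of the compound), where compound 2 gives 25 mL.min-1.g-1. Its partner compound 1, `Nc1nc(C(F)(F)F)cc2c1[nH]c(=O)n2Cc1ccc(NCc2ccccc2)nc1`, has methyl(2-(piperidin-1-yl)ethyl)amino replaced by benzylamino on an aromatic carbon; in this assay compound 1 reaches only a limit of the method, < 8 mL.min-1.g-1, as noted in the limit of < 8 mL.min-1.g-1 in this assay, at which 1 of the 2 values shown sits. Among the compounds with values here, the one measured step is therefore an at least 3.1-fold higher number from compound 1 to compound 2 (0.49 log units; beyond the scatter), bounded on one side by that limit. Compound 3, `Nc1nc(C(F)(F)F)cc2c1[nH]c(=O)n2Cc1ccc(NCCN2CCCC2)nc1`, differs from compound 2 by (2-(pyrrolidin-1-yl)ethyl)amino in place of methyl(2-(piperidin-1-yl)ethyl)amino on an aromatic carbon. Within the data shown here, the single measured step concerns a different exchange at the same aromatic carbon and gives only a lower bound, so it bears on this change only loosely. The estimate for compound 3 in this assay is 15 mL.min-1.g-1, with a range from 6 mL.min-1.g-1 to 35 mL.min-1.g-1, which means an expected step of a 1.7-fold lower number from compound 2 to compound 3 (0.22 log units; within the scatter), and it may again fall at the limit.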

Compound 3, intrinsic clearance in microsomes in the Homo sapiens assay: 8.5 mL.min-1.g-1
Compound 3: the middle estimate sits 1.8-fold (0.25 log units) above what was measured, and the stated range covers the measured number.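

Going by these compounds alone, in the Homo sapiens assay, (2-(pyrrolidin-1-yl)ethyl)amino in place of methyl(2-(piperidin-1-yl)ethyl)amino on this aromatic carbon gives a 2.9-fold lower number from compound 2 to compound 3 (0.47 log units; beyond the scatter), the first step here measured between two numbers. In a physicochemical assay for lipophilicity (on this read-out lower numbers stand for lower lipophilicity and higher numbers for higher lipophilicity), compound 2 gives 1.8 and compound 3 gives 0.8, which sets a number 1.00 log units lower from compound 2 to compound 3 (beyond the scatter) alongside the slower removal. In the Homo sapiens assay compound 1 gives only a limit of the assay, < 8 mL.min-1.g-1. In the Homo sapiens assay, (pyrrolidin-1-yl)methyl in place of phenyl on a saturated chain carbon bound to a nitrogen on an aromatic ring gives an at least 1.0-fold higher number from compound 1 to compound 3 (0.02 log units; that floor lies within the scatter), a step bounded on one side by that limit.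

The exchange alters the ring size, the chain's amine substitution and the count of hydrogen-bond donors at once, and the compounds shown do not separate these changes or show whether the two shifts are linked. A morpholine ring or a longer chain between the two nitrogens would be untested variations at this carbon.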